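The source may hold more compounds than are shown below. What is called first, only, known or untested is meant among the compounds shown, and "the series" means these compounds.

In a functional assay on A-375 cells (Homo sapiens) for antiproliferative activity, read by MTT assay, with a stated time of 72 h (on this read-out higher numbers stand for weaker inhibition and lower numbers for stronger inhibition), compound 1 (`CC(C)N1C(=O)COc2ccc(-c3cnc(Cl)c(NS(=O)(=O)c4ccc(F)cc4)c3)cc21`), with isopropyl on the amide-type nitrogen in a ring, gives 25500 nM. Compound 2 (`O=C1COc2ccc(-c3cnc(Cl)c(NS(=O)(=O)c4ccc(F)cc4)c3)cc2N1c1ccc(F)cc1`), with 4-fluorophenyl at that nitrogen, gives > 40000 nM, which is a limit of the assay and not a number. Its standing is therefore known only as the limit of > 40000 nM in this assay, at which 1 of the 2 values shown sits. Compound 3 (`O=C1COc2ccc(-c3cnc(Cl)c(NS(=O)(=O)c4ccc(F)cc4)c3)cc2N1`) differs from compound 2 by hydrogen in place of 4-fluorophenyl on an amide-type nitrogen in a ring. Among the compounds with values here, the one measured step at this nitrogen is an at least 1.5-fold higher number from compound 1 to compound 2 (0.19 log units; that floor lies within the scatter), and as a floor it fixes no size. Within the data shown here, with compound 1 at 25500 nM as the only number at this nitrogen, a modest step toward stronger inhibition in this assay is expected. The expected step is an at least 1.8-fold lower number from compound 2 to compound 3 (0.25 log units; that floor lies within the scatter). For compound 3 the estimated value is 22000 nM, within an expected range of 8000 nM to 40000 nM.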

Compound 3, half-maximal inhibitory concentration: > 40000 nM
Compound 3 was reported as a limit; the forecaster's own chance of this, stated with the estimate: 30%; middle value at least 1.8-fold (0.25 log units) away from the limit.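

In this assay compound 3, with hydrogen on the amide-type nitrogen in a ring, gives > 40000 nM, which is a limit of the assay and not a number. The change from isopropyl to hydrogen reads as an at least 1.5-fold higher number from compound 1 to compound 3 (0.19 log units; that floor lies within the scatter), a floor that fixes no size, and the step between compound 2 and compound 3 cannot be read, since both values are limits. Compound 1 therefore remains the only one with a number at this nitrogen, while hydrogen and 4-fluorophenyl share one limit: the limit of > 40000 nM in this assay, at which 2 of the 3 values shown sit.

As far as these compounds go, it remains open whether methyl, ethyl or a chain ending in an amine at this nitrogen would give a number in this assay. From the compounds shown here alone, how compound 2 and compound 3 actually compare with each other also remains open.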